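Sulfonyl tetralin series: amine replacement on the benzylic chain

This account rests on a few compounds, and the source may have more. Where it says the series, first, only, none or still open, it means among the compounds named here.

Measured so far:
compound 1 `COc1cccc(S(=O)(=O)c2ccc3c(c2)CCC[C@H]3CN)c1`, 0.398 nM
compound 2 `NC[C@@H]1CCCc2cc(S(=O)(=O)c3cc(F)cc4[nH]cnc34)ccc21`, 5.01 nM
compound 3 `O=C1CN(C[C@@H]2CCCc3cc(S(=O)(=O)c4cccc(F)c4)ccc32)CCN1`, 6.31 nM

In an assay on isolated protein for displacement of a labelled ligand from 5-hydroxytryptamine receptor 6 (Homo sapiens) (on this read-out lower numbers stand for stronger inhibition and higher numbers for weaker inhibition), compound 3 gives the highest number of the three. Its nearest neighbour is compound 2, a gap within the usual scatter; compound 1 lies well beyond the scatter with a much lower number.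

Compound 4 `NS(=O)(=O)NC[C@@H]1CCCc2cc(S(=O)(=O)c3cccc(F)c3)ccc21` is not yet measured. Relative to compound 3 the change is sulfamoylamino in place of 3-oxopiperazin-1-yl on a saturated chain carbon bound to a saturated ring carbon.

Among the compounds with values here, no measured pair shows this exact exchange, so the expectation rests on compound 3 alone. The step of a 4.0-fold higher number from compound 3 to compound 4 (0.60 log units; beyond the scatter) is expected to run toward a higher number, of moderate size, beyond the scatter. Compound 4 is estimated at 25 nM, within 6 nM to 100 nM.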

Compound 4, inhibition constant: 0.126 nM
Beside the measured number, compound 4's estimate is 200-fold (2.30 log units) above it; measured number below the stated range.
By their numbers in this assay, from the lowest: compound 4; then compound 1; then compounds 2 and 3 (each within the scatter of the next).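

In this assay, the group on the saturated chain carbon bound to a saturated ring carbon has a large influence on the number: sulfamoylamino in place of 3-oxopiperazin-1-yl gives a 50-fold lower number from compound 3 to compound 4 (1.70 log units; beyond the scatter) on an otherwise unchanged structure. In this pair, the six-membered ring is not needed at this place for a low number. No available evidence accounts for the size of this step.

Open, on these data alone, is whether a urea or a methanesulfonylamino group at this place gives a similarly low number, and whether the step holds with other aryl sulfonyl groups on the shared core.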